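Hydrazone aryl variation in a benzothiazole series: compound 4

This account rests on a few compounds, and the source may have more. Where it says the series, first, only, none or still open, it means among the compounds named here.

The shared core is held fixed across compound 1 `O=C(N/N=C/c1cccc(O)c1O)c1ccc(-c2nc3ccccc3s2)cc1`, compound 2 `O=C(N/N=C/c1ccc(O)c(O)c1)c1ccc(-c2nc3ccccc3s2)cc1` and compound 3 `COc1ccc(/C=N/NC(=O)c2ccc(-c3nc4ccccc4s3)cc2)cc1`; only the aryl on the carbon double-bonded to nitrogen changes. In an assay on isolated protein for inhibition of Maltase-glucoamylase (Homo sapiens), with a stated time of 15 min (on this read-out lower numbers stand for stronger inhibition and higher numbers for weaker inhibition), compound 1 gives 11200 nM, compound 2 gives 15100 nM and compound 3 gives 18300 nM. Compound 3 shows the highest of the three numbers, but a 1.6-fold higher number from compound 1 to compound 3 (0.21 log units; within the scatter) and a 1.2-fold higher number from compound 2 to compound 3 (0.08 log units; within the scatter) both stay within the scatter, as does a 1.3-fold higher number from compound 1 to compound 2 (0.13 log units; within the scatter).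

Compound 4 `COc1ccc(/C=N/NC(=O)c2ccc(-c3nc4ccccc4s3)cc2)c(I)c1O` differs from compound 3 by 3-hydroxy-2-iodo-4-methoxyphenyl in place of 4-methoxyphenyl on a carbon with a double bond to nitrogen. Among the measured compounds shown here, the steps from compound 1 and compound 2 to compound 3 bear on this change, since each adds or removes hydroxyl on the aryl, and none moved the number beyond the scatter; iodine has no precedent in the set. A step of a 1.2-fold lower number from compound 3 to compound 4 (0.09 log units; within the scatter) is therefore expected, that is, none beyond the scatter. Compound 4 is estimated at 15000 nM, with a range from 6000 nM to 40000 nM.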

Compound 4, half-maximal inhibitory concentration: 44800 nM
Estimate against measurement, compound 4: 3.0-fold (0.48 log units) below, and the stated range ends below it.
By their numbers in this assay, from the lowest: compounds 1, 2 and 3 (each within the scatter of the next); then compound 4.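

The aryl on the carbon with a double bond to nitrogen is less indifferent than compound 1, compound 2 and compound 3 suggested: 3-hydroxy-2-iodo-4-methoxyphenyl gives steps beyond the scatter, with a 2.4-fold higher number from compound 3 to compound 4 (0.39 log units; beyond the scatter), a 3.0-fold higher number from compound 2 to compound 4 (0.47 log units; beyond the scatter) and a 4.0-fold higher number from compound 1 to compound 4 (0.60 log units; beyond the scatter). All three steps are modest and run towards a higher number, setting compound 4 apart from the other compounds. No available evidence bears on the origin of this step.

Compound 4 brings in iodine and an extra hydroxyl together, leaving their separate contributions open. Going by these compounds, whether an amine or a carboxylic acid on this aryl would move the number in either direction also remains open.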